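The compounds below may be only part of what the source reports. "The series", "measured", "known", "first", "only" and "open" are said of these compounds alone.

The measured compounds stand as follows. Compound 1 `CC1CCN(c2nc(-c3ccccc3)nc3ccccc23)CC1` gives 69% in a functional assay on the whole organism for inhibition, with Rattus norvegicus as the target, read by paw edema, with stated times of 4 days, 1 h and 2 h, at a dose of 100 mg/kg by the oral route; on this read-out higher numbers stand for more inhibition at the one dose given (going by the name of the read-out) and lower numbers for less inhibition. Compound 2 `CC1CCN(c2nc(-c3ccc(Cl)cc3)nc3ccccc23)CC1` gives 55.1% in this assay. Compound 3 `Clc1ccc(-c2nc(N3CCC(c4ccccc4)CC3)c3ccccc3n2)cc1` gives 53.7% in this assay.

Among these three, compound 2 holds the second highest number. Its nearest neighbour is compound 3, reached by phenyl in place of methyl on a saturated ring carbon, and that step, a number 1.4 percentage points lower from compound 2 to compound 3 (within the scatter), is within the scatter, so the two read as equivalent. Its furthest neighbour is compound 1, and the step of a number 13.9 percentage points lower from compound 1 to compound 2 (beyond the scatter), chloro in place of hydrogen on an aromatic carbon, lies beyond the scatter.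

Compound 4 `CC1CCN(c2nc(-c3ccc(Cl)cc3)nc3ccc(I)cc23)CC1` is not yet measured. It differs from compound 2 by iodo in place of hydrogen on an aromatic carbon. Among the measured compounds shown here, the only measured step that bears on it is the one from compound 1 to compound 2, where a halogen also replaced hydrogen on an aromatic carbon, though on a different ring; that step was a number 13.9 percentage points lower from compound 1 to compound 2 (beyond the scatter), a modest loss. For the measured compounds named here, no measured step touches the fused ring of the shared core, so the direction is uncertain. A small drop or no change beyond the scatter is expected in this assay, as a step of a number 5.1 percentage points lower from compound 2 to compound 4 (within the scatter). Compound 4 is therefore estimated to give 50%, within 33% to 67%.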

Compound 4, a percentage reported as inhibition, in the whole organism at one dose (the size of the read-out at that dose, not a potency): 45.8%
The estimate for compound 4 lay 4.2 percentage points above the measured number, within the range that was stated.
By their numbers in this assay, from the lowest: compounds 4, 3 and 2 (each within the scatter of the next); then compound 1.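

Among the compounds shown here, with compound 4, a substituent appears for the first time on the fused part of the shared core, on an aromatic carbon of a six-membered aromatic ring of carbon only, and in this assay the step, a number 9.3 percentage points lower from compound 2 to compound 4 (within the scatter), cannot be told apart from repeat scatter. For the compounds shown here, this carbon therefore takes a single iodine atom, a large addition in a place that no earlier compound varied, without a change that this whole-animal read-out can resolve. The earlier halogen step, a number 13.9 percentage points lower from compound 1 to compound 2 (beyond the scatter), lay beyond the scatter, but it was a chloro on a different ring, so the two steps show only that a halogen on one ring and a halogen on the other need not read alike, not that a general rule separates them.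

No measurement among the data speaks to the reason for this result.

The compounds shown leave open how a fluoro, a methoxy or an amino group would read on this same carbon, and whether iodo would give a comparable step on compound 1, which carries no chloro. They also leave open whether a carboxylic acid or a longer chain at this carbon would move the number beyond the scatter.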